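The compounds below may be only part of what the source reports. "The series", "measured", "known", "first", "only" and "open" are said of these compounds alone.

Compound 1 `CN(C)CCCNc1nc(-c2ccc(NC(=O)Nc3ccc(F)cc3)cc2)nc2c(Cl)c(Cl)sc12` is the reference point here. In a functional assay on NCI-H460 cells (Homo sapiens) for cytotoxicity, read by MTT assay, with a stated time of 72 h (a higher number here means a weaker inhibitor, a lower number a stronger inhibitor), compound 1 gives 650 nM, the higher of the two numbers in hand, while compound 2 `CN(C)CCNc1nc(-c2ccc(NC(=O)Nc3ccc(F)cc3)cc2)nc2ccsc12` gives 390 nM in this assay; the two numbers lie within the scatter of each other, so the data do not separate them. Compound 2 differs from compound 1 in more than one place, so no single step can be read from that pair.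

Compound 3 `Cc1ccc(NC(=O)Nc2ccc(-c3nc(NCCCN(C)C)c4sc(Cl)c(Cl)c4n3)cc2)cc1` is not yet measured in this assay. It differs from compound 1 by methyl in place of fluoro on an aromatic carbon, para to a large group. Within the data shown here, no measured pair shows this change, so the expectation rests on compound 1 alone. The step of a 1.1-fold lower number from compound 1 to compound 3 (0.03 log units; within the scatter) is expected to stay within the scatter, with no clear direction. Compound 3 is therefore estimated at 600 nM, with a range from 250 nM to 1500 nM.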

Compound 3, half-maximal inhibitory concentration: 1110 nM
Compound 3: the middle estimate sits 1.9-fold (0.27 log units) below what was measured; measured number inside the range.
By their numbers in this assay, from the lowest: compounds 2, 1 and 3 (each within the scatter of the next, the first and the last beyond it).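

Among these compounds, the swap of fluoro for methyl on an aromatic carbon, para to a large group, gives a 1.7-fold higher number from compound 1 to compound 3 (0.23 log units; within the scatter) in this assay, and it is the first change in a single place that can be read here. The 4-fluorophenyl and 4-methylphenyl groups are therefore not separated at this position, so this place accepts either group without a change that the data can distinguish. No measurement is available that bears on this result.

The compounds shown leave open whether trifluoromethyl, methoxy or a plain phenyl at this place would give a number beyond the scatter of compound 1. They also leave open whether the same swap of fluoro for methyl would read the same way on the core of compound 2.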